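This account rests on a few compounds, and the source may have more. Where it says the series, first, only, none or still open, it means among the compounds named here.

Measured compounds:
Compound 1 `CC1=CC[C@@H]([C@@](C)(O)CCCC(C)(C)NC(=S)NN)CC1` — in a functional assay on OVCAR-3 cells (Homo sapiens) for cytotoxicity, read by sulforhodamine B assay (on this read-out lower numbers stand for stronger inhibition of growth and higher numbers for weaker inhibition of growth), compound 1 gives only a limit, > 100000 nM.
Compound 2 `CC1=CC[C@@H]([C@@](C)(O)CCCC(C)(C)NC(=S)N/N=C\c2ccccc2)CC1` — in this assay compound 2 gives 12900 nM.

Among the measured compounds shown here, compound 2 holds the only number among the values shown; the other entry is a limit, as noted for compound 1 at the limit of > 100000 nM in this assay, at which 1 of the 2 values shown sits. Compound 3 `CC1=CC[C@@H]([C@@](C)(O)CCCC(C)(C)NC(=S)N/N=C\c2ccc(C)cc2)CC1` carries methyl in place of hydrogen on an aromatic carbon, read one bond further out as phenyl to 4-methylphenyl. For the measured compounds named here, the one measured step, an at least 7.7-fold lower number from compound 1 to compound 2 (0.88 log units; beyond the scatter), concerns a different site and gives no direct guide to a methyl on the aromatic ring. No change beyond the scatter in this assay is expected, so compound 3 is estimated at 10000 nM (range 4000 nM to 30000 nM), a step of a 1.3-fold lower number from compound 2 to compound 3 (0.11 log units; within the scatter).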

Compound 3, concentration for total growth inhibition: 11800 nM
Beside the measured number, compound 3's estimate is 1.2-fold (0.07 log units) below it; low and high end bracket the measured number.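

Methyl on the aromatic ring, para to a large group, leaves the number in this assay essentially where it was, the step being a 1.1-fold lower number from compound 2 to compound 3 (0.04 log units; within the scatter). With 4-methylphenyl in place of phenyl, the difference from the unsubstituted end of the chain persists, at an at least 8.4-fold lower number from compound 1 to compound 3 (0.92 log units; beyond the scatter). Compound 1 gives only a limit, so both steps from it have no fixed size: the limit of > 100000 nM in this assay, at which 1 of the 3 values shown sits.

From the compounds shown here alone, whether an amine, a carboxylic acid or a methoxy group at this ring position would move the number beyond the scatter remains open. So does the effect of a longer chain there.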